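The source may report more compounds than this note shows. Statements on the series, on what has been measured and on what is new or still open speak of the compounds shown alone.

Measured in a functional assay on MCF7 cells (Homo sapiens) for cytotoxicity, read by MTT assay, with a stated time of 48 h; on this read-out higher numbers stand for weaker inhibition and lower numbers for stronger inhibition:
- compound 1 `COc1cc(N/C=C\C(=O)c2c(-c3ccc(Cl)cc3)nc3ccccn23)cc(OC)c1`: 13600 nM
- compound 2 `O=C(/C=C\Nc1ccc2[nH]ccc2c1)c1c(-c2ccc(Cl)cc2)nc2ccccn12`: 7130 nM

Compound 2 stands within the scatter of compound 1 in this assay, so the two numbers set no clear order between these compounds. Compound 3 `O=C(/C=C\Nc1cnc2ccccc2c1)c1c(-c2ccc(Cl)cc2)nc2ccccn12` keeps the shared core and changes only the group on the amine nitrogen: quinolin-3-yl in place of 1H-indol-5-yl on an amine nitrogen. In words, quinolin-3-yl stands in place of 1H-indol-5-yl on an amine nitrogen.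

Within the data shown here, one measured step bears on this change, as it concerns the same nitrogen: a 1.9-fold lower number from compound 1 to compound 2 (0.28 log units; within the scatter). That exchange of one group for a quite different one stayed within the scatter, although a single step is thin evidence. Among the measured compounds shown here, no measured compound carries quinolin-3-yl, so the data give no direct reading of that group. No step beyond the scatter is therefore expected in this assay, in either direction. The expected step is a 1.1-fold higher number from compound 2 to compound 3 (0.05 log units; within the scatter). Compound 3 is estimated at 8000 nM, with an expected range of 2500 nM to 25000 nM.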

Compound 3, half-maximal inhibitory concentration: 18900 nM
Estimate against measurement, compound 3: 2.4-fold (0.37 log units) below, within the range that was stated.
By their numbers in this assay, from the lowest: compounds 2, 1 and 3 (each within the scatter of the next, the first and the last beyond it).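

In this assay, the group on this amine nitrogen now produces a step beyond the scatter, though a modest one: a 2.7-fold higher number from compound 2 to compound 3 (0.42 log units; beyond the scatter), with quinolin-3-yl in place of 1H-indol-5-yl. The position is therefore not indifferent to the group it carries, which the earlier step, within the scatter, could not show. Yet the exchange of 3,5-dimethoxyphenyl for quinolin-3-yl gives only a 1.4-fold higher number from compound 1 to compound 3 (0.14 log units; within the scatter), also within the scatter, so just one of the three pairs separates, and no measurement links that separation to any particular difference between the two groups.

The change from compound 2 to compound 3 alters several things at once: the five-membered ring gives way to a six-membered one, and the hydrogen-bond donor is lost while a ring nitrogen acceptor enters. The compounds shown therefore leave open which of these matters, and a naphthalen-2-yl group, with two six-membered rings of carbon only, or a benzofuran-5-yl group, with a five-membered ring holding oxygen, would help to separate them.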